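The compounds below may be only part of what the source reports. "The series", "measured", "known", "first", "only" and "open" are said of these compounds alone.

Working notes on the series. Compound 1 `C=C1C(=O)[C@@]23C(=O)OC[C@]4(C(=O)CCC(C)(C)[C@H]4C=O)[C@@H]2CC[C@@H]1[C@H]3OC(C)=O` and compound 2 `C=C1C(=O)[C@@]23C(=O)OC[C@]4(C(=O)CCC(C)(C)[C@H]4C=O)[C@@H]2CC[C@@H]1[C@H]3OC(=O)CC` share one core and differ only in the acyl chain of the ester. In a functional assay on Bel-7402 cells (Homo sapiens) for cytotoxicity, read by MTT assay, with a stated time of 72 h (on this read-out lower numbers stand for stronger inhibition and higher numbers for weaker inhibition), compound 1 gives 1730 nM and compound 2 gives 1650 nM. Among the measured compounds shown here, the one measured step, a 1.0-fold lower number from compound 1 to compound 2 (0.02 log units; within the scatter), is within the scatter, so the two compounds cannot be told apart on this read-out. Of the two numbers compound 2 carries nominally the smaller, its nearest neighbour being compound 1 at a gap within the scatter. Compound 3 `C=C1C(=O)[C@@]23C(=O)OC[C@]4(C(=O)CCC(C)(C)[C@H]4C=O)[C@@H]2CC[C@@H]1[C@H]3OC(=O)c1ccccc1Cl` is the next member: 2-chlorophenyl in place of ethyl on a carbonyl carbon. For the measured compounds named here, no measured step bears directly on this change; the only step available, from compound 1 to compound 2, swaps methyl for hydrogen and moves nothing beyond the scatter. On that evidence no step beyond the scatter is expected in this assay for compound 3, and the estimated step is a 1.1-fold lower number from compound 2 to compound 3 (0.04 log units; within the scatter). The range is set wide: no aromatic ester has been measured in this assay. Compound 3 is thus expected at about 1500 nM, between 400 nM and 5000 nM.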

Compound 3, half-maximal inhibitory concentration: 2890 nM
Estimate against measurement, compound 3: 1.9-fold (0.28 log units) below, within the range that was stated.
By their numbers in this assay, from the lowest: compounds 2, 1 and 3 (each within the scatter of the next).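

The ester position now carries a six-membered aromatic ring as well as short alkyl chains, and in this assay the change to 2-chlorophenyl stays within the scatter from either alkyl ester (a 1.8-fold higher number from compound 2 to compound 3 (0.24 log units; within the scatter); a 1.7-fold higher number from compound 1 to compound 3 (0.22 log units; within the scatter)). The earlier pair covered only a methyl-for-hydrogen change on the chain, whereas this change replaces ethyl with a group of seven heavy atoms, including a chlorine, on the same carbonyl carbon. Even so, the propanoyl, acetyl and (2-chlorophenyl)carbonyl esters cannot be told apart on this read-out, and no evidence on hand bears on this result.

Open, as far as these compounds go, is whether the chlorine has any part in this result, a question that a plain phenyl ester or a 4-chlorophenyl ester would address. Also open, from the compounds shown here alone, is whether an acyl group carrying an amine or a carboxylic acid, a much longer alkyl chain, or a free hydroxyl in place of the ester would produce a step beyond the scatter at this position.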